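Ring closure of the amine side chain on the shared core

This account rests on a few compounds, and the source may have more. Where it says the series, first, only, none or still open, it means among the compounds named here.

Compound 1 `C=C(C)CN(CC)Cc1c(C(F)(F)F)nc2n(-c3c(C)cc(C)cc3C)c(Cl)cn12`: 67 nM
Compound 2 `CCN(Cc1ccccc1)Cc1c(C(F)(F)F)nc2n(-c3c(C)cc(C)cc3C)c(Cl)cn12`: 350 nM

Among the compounds with values here, in an assay on cells for displacement of a labelled ligand from corticotropin-releasing factor receptor 1 (Homo sapiens), with a stated time of 100 min (a lower number here means a stronger inhibitor, a higher number a weaker inhibitor), compound 2 stands at the weak end of the two measured compounds, with compound 1 the only neighbour at a 5.2-fold higher number from compound 1 to compound 2 (0.72 log units; beyond the scatter). Compound 3 `Cc1cc(C)c(-n2c(Cl)cn3c(CN4CCC(c5ccccc5)C4)c(C(F)(F)F)nc23)c(C)c1` differs from compound 2 by 3-phenylpyrrolidin-1-yl in place of benzyl(ethyl)amino on a saturated chain carbon bound to an aromatic carbon. Within the data shown here, no measured step closes the amine substituent into a ring; the single known step concerns a different exchange on that nitrogen, so it gives little guidance. Compound 3 is therefore expected to show no change beyond the scatter, an estimated 1.3-fold lower number from compound 2 to compound 3 (0.10 log units; within the scatter), giving 280 nM within 60 nM to 1300 nM.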

Compound 3, inhibition constant: 610 nM
Beside the measured number, compound 3's estimate is 2.2-fold (0.34 log units) below it, within the range that was stated.
By their numbers in this assay, from the lowest: compound 1; then compounds 2 and 3 (each within the scatter of the next).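

In this assay, closing the amine into 3-phenylpyrrolidin-1-yl gives a number within the scatter of the open benzyl(ethyl)amino group (a 1.7-fold higher number from compound 2 to compound 3 (0.24 log units; within the scatter)), so ring closure does not separate these two phenyl-bearing amines. Set against ethyl(2-methylprop-2-en-1-yl)amino, the same ring is clearly weaker (a 9.1-fold higher number from compound 1 to compound 3 (0.96 log units; beyond the scatter)). Nothing measured here explains either result.

The compounds shown leave open whether a pyrrolidine without the phenyl, a 4-phenylpiperidine or a morpholine on the same saturated chain carbon would come closer to compound 1.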